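The source may hold more compounds than are shown below. What is called first, only, known or untested is meant among the compounds shown, and "the series" means these compounds.

Three compounds have been measured in a functional assay on DU-145 cells (Homo sapiens) for inhibition, read by trypan blue exclusion, with a stated time of 96 h; a higher number here means a weaker inhibitor of growth, a lower number a stronger inhibitor of growth:

compound 1 `O=C(/C(=C\c1ccc(Br)cc1)Sc1ccccc1Br)c1ccc(Br)cc1` gives 1000 nM;
compound 2 `O=C(/C(=C\c1ccccc1O)Sc1ccccc1Br)c1ccc(Br)cc1` gives 50000 nM;
compound 3 `O=C(/C(=C\c1ccc(Br)cc1)S(=O)(=O)c1ccc(Br)cc1)c1ccc(Br)cc1` gives 10000 nM.

Compound 1 and compound 2 share one core and differ in a single place, namely (2-hydroxyphenyl in place of 4-bromophenyl on a double-bonded chain carbon bound to a double-bonded chain carbon). That single change produced a 50-fold higher number from compound 1 to compound 2 (1.70 log units; beyond the scatter), a marked loss of growth inhibition. Compound 3 sits on a second core; the difference between the two cores is not broken down here. Its value in this assay places compound 3 between the other two, with a higher number than compound 1 and a lower number than compound 2, both gaps beyond the scatter.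

Compound 4 `O=C(/C(=C\c1ccc(Br)cc1)S(=O)(=O)c1ccc(Br)cc1)c1ccccc1O` has not been measured. It differs from compound 3 by 2-hydroxyphenyl in place of 4-bromophenyl on a carbonyl carbon. Going by the values given here, this is the same kind of change as the one from compound 1 to compound 2, but not the same change: there the place was on a double-bonded chain carbon bound to a double-bonded chain carbon, whereas here it is on a carbonyl carbon whose other neighbour is a double-bonded chain carbon. Among the compounds with values here, the only measured precedent is a 50-fold higher number from compound 1 to compound 2 (1.70 log units; beyond the scatter), so a weakening is expected, estimated as a 5.0-fold higher number from compound 3 to compound 4 (0.70 log units; beyond the scatter). Within the data shown here, no measured pair covers the shift of place, and the range is therefore kept wide. Compound 4 is expected to come in at about 50000 nM, somewhere between 10000 nM and 250000 nM.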

Compound 4, concentration for 50% growth inhibition: > 100000 nM
Compound 4 ended at the assay's limit; the forecaster's own chance of this, stated with the estimate: 25%; middle value at least 2.0-fold (0.30 log units) from the limit.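

In this assay compound 4 gives > 100000 nM, which is a limit of the assay and not a number. Placing 2-hydroxyphenyl where 4-bromophenyl stood on a carbonyl carbon cost growth inhibition on the core of compound 3, an at least 10-fold higher number from compound 3 to compound 4 (1.00 log units; beyond the scatter), so the loss seen on the core of compound 1, a 50-fold higher number from compound 1 to compound 2 (1.70 log units; beyond the scatter), has a counterpart on a second core, although the change sits at a different place in each pair. The two pairs show that the direction of the change held in both cases, but they do not show whether its size carries over from one core to the other: the same change on two cores in this assay, a 50-fold higher number (1.70 log units; beyond the scatter) from compound 1 to compound 2 and an at least 10-fold higher number (1.00 log units; beyond the scatter) from compound 3 to compound 4; the limit leaves it open whether they differ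

The compounds shown leave open whether the step follows from gaining the hydroxy group or from losing the bromine, since no ring bearing a methoxy group, an amine or a carboxylic acid stands in that place, and no unsubstituted phenyl does either. They also leave open how the same change would behave with the two places exchanged on a single core, and how much of the gap between the two cores belongs to the sulfonyl group itself.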